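Toward the free hydroxy analogue of compound 3

The compounds below may be only part of what the source reports. "The series", "measured", "known", "first", "only" and "open" are said of these compounds alone.

Compound 1 `CCCOc1ccc2ccc(=O)oc2c1CN1CCc2ccccc2C1`, compound 2 `Cc1cc(=O)oc2c(CN3CCc4ccccc4C3)c(O)ccc12` and compound 3 `O=C(Oc1ccc2ccc(=O)oc2c1CN1CCc2ccccc2C1)c1ccccc1` share one core. In an ADME assay on MT4 cells (Homo sapiens) for cytotoxicity, read by MTT assay, with a stated time of 96 h (on this read-out higher numbers stand for lower toxicity in this test and lower numbers for higher toxicity in this test), compound 1 gives 11000 nM. Compound 2 reaches only the limit of > 100000 nM. Compound 3 likewise reaches only the limit of > 100000 nM in this assay. Compound 3 thus stands at the limit of > 100000 nM in this assay, at which 2 of the 3 values shown sit. Among the measured compounds shown here, the single measured step, an at least 9.0-fold higher number from compound 1 to compound 3 (0.95 log units; beyond the scatter), moves the number up onto that limit. Compound 4 `O=c1ccc2ccc(O)c(CN3CCc4ccccc4C3)c2o1` differs from compound 3 by hydrogen in place of benzoyl on an oxygen on an aromatic ring. For the measured compounds named here, no measured step carries this change; compound 2, which also bears a hydroxy group, sits at the limit as well. Compound 4 is therefore expected to remain at a limit, with a number no higher from compound 3 to compound 4 (the limit leaves the size open) estimated as no step beyond the scatter. The estimate for compound 4 in this assay is 100000 nM, range 30000 nM to 300000 nM.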

Compound 4, half-maximal cytotoxic concentration: > 100000 nM
Compound 4: no number, only a limit; the forecaster's own chance of this, stated with the estimate: 70%; the middle value sits exactly at the limit.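

In this assay compound 4 gives > 100000 nM, a limit and not a number. With hydrogen in place of propyl on the oxygen on the aromatic ring, the series shows an at least 9.0-fold higher number from compound 1 to compound 4 (0.95 log units; beyond the scatter), so the free hydroxy group, like benzoyl, leaves the number at the limit, whereas propyl gives a readable value. The steps among compound 2, compound 3 and compound 4 cannot be read, and the limit now holds most of the series: the limit of > 100000 nM in this assay, at which 3 of the 4 values shown sit.

Going by these compounds, whether a longer chain such as butyl, or an amine, on this oxygen gives a readable value remains open. So does any order among the three compounds at the limit.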